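From an Indolylmethyl Amine to a tert-Butyl Carbonyl Analogue

This account rests on a few compounds, and the source may have more. Where it says the series, first, only, none or still open, it means among the compounds named here.

Within the data shown here, compound 2 `Fc1ccc(C(SCCNC2CCN(Cc3cc4ccccc4[nH]3)CC2)c2ccc(F)cc2)cc1` holds the lowest of the two numbers measured so far in an assay on membranes from Cortex for displacement of a labelled ligand from Sigma non-opioid intracellular receptor 1 (Cavia porcellus), read by scintillation counting, with a stated time of 120 min; a higher number here means a weaker inhibitor, a lower number a stronger inhibitor: compound 2 gives 205 nM, whereas compound 1 `O=C(c1cc2ccccc2[nH]1)N1CCC(NCCSC(c2ccc(F)cc2)c2ccc(F)cc2)CC1` gives 1130 nM. Among the measured compounds shown here, the single recorded step, a 5.5-fold lower number from compound 1 to compound 2 (0.74 log units; beyond the scatter), shows that trading the carbonyl-linked indole for its methylene-linked counterpart on the ring nitrogen lowered the number by a modest but clear amount. Compound 3 `CC(C)(C)C(=O)N1CCC(NCCSC(c2ccc(F)cc2)c2ccc(F)cc2)CC1` differs from compound 2 by (tert-butyl)carbonyl in place of (1H-indol-2-yl)methyl on an amine nitrogen in a ring. For the measured compounds named here, this change runs against that step: a carbonyl again sits on the ring nitrogen, while the indole is lost entirely, a loss for which no measured counterpart exists here. Given a 5.5-fold lower number from compound 1 to compound 2 (0.74 log units; beyond the scatter), a rise of similar or larger size is expected for compound 3 in this assay. Compound 3 is thus estimated at 1800 nM, within 450 nM to 7000 nM. That estimate means a step of an 8.8-fold higher number from compound 2 to compound 3 (0.94 log units; beyond the scatter).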

Compound 3, inhibition constant: 163 nM
Compound 3: the middle estimate sits 11-fold (1.04 log units) above what was measured; the measured number lies below the stated range.
By their numbers in this assay, from the lowest: compounds 3 and 2 (each within the scatter of the next); then compound 1.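

In this assay, an indole is not needed for the lower numbers at this place, on an amine nitrogen in a ring: with the carbonyl kept, tert-butyl in place of 1H-indol-2-yl goes with a 6.9-fold lower number from compound 1 to compound 3 (0.84 log units; beyond the scatter). A carbonyl on this nitrogen is thus not tied to the higher number of compound 1, and (tert-butyl)carbonyl and (1H-indol-2-yl)methyl cannot be told apart here, with a 1.3-fold lower number from compound 2 to compound 3 (0.10 log units; within the scatter), although only the second carries a ring. Nothing available explains these results.

Going by these compounds, it remains open whether a smaller or ring-bearing group on the same carbonyl, such as methyl or cyclohexyl, would match tert-butyl. Also open, on these data alone, is whether a neopentyl group, the methylene-linked counterpart of (tert-butyl)carbonyl, would give a number like that of compound 3 or a different one.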